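Methoxy to Ethoxy on a Weak Nicotinic Antagonist

A few compounds are considered here, and "the series" means these few. Any claim that something is new, unique, unknown or untested is made for them only; others in the source may bear on it.

Among the measured compounds shown here, in an assay on HEK293 cells for antagonist activity at Nicotinic acetylcholine receptor alpha-4/beta-2 (Mus musculus), read by FLIPR, using a membrane potential dye (on this read-out lower numbers stand for stronger inhibition and higher numbers for weaker inhibition), compound 2 `CO[C@H]1CC=C2CCN(C)[C@H]2C1` gives 30000 nM, the only plain number among the two values shown. Compound 1 `COCCO[C@H]1CC[C@H]2CCN(C)[C@H]2C1` reaches only a limit of the method, > 300000 nM; this is the limit of > 300000 nM in this assay, at which 1 of the 2 values shown sits. Compound 3 `CCO[C@H]1CC=C2CCN(C)[C@H]2C1` is not yet measured. It differs from compound 2 by methyl in place of hydrogen on a saturated chain carbon bound to an oxygen on a saturated carbon, a methyl in place of hydrogen on a saturated chain carbon bound to an oxygen on a saturated carbon, so methoxy becomes ethoxy. For the measured compounds named here, no measured pair shows what such a change does here. The step of no change at the digits printed from compound 2 to compound 3 (within the scatter) is expected to stay within the usual scatter, with no clear direction. Compound 3 is estimated at 30000 nM, with a range from 10000 nM to 100000 nM.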

Compound 3, half-maximal inhibitory concentration: > 300000 nM
Compound 3 ended at the assay's limit; the forecaster's own chance of this, stated with the estimate: 25%; middle value at least 10-fold (1.00 log units) from the limit.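

In this assay, among the compounds shown here, this is the first measured pair to show what the change does: a single added methyl, turning methoxy into ethoxy, gives an at least 10-fold higher number from compound 2 to compound 3 (1.00 log units; beyond the scatter). The value of compound 3, > 300000 nM, is a limit of the assay and not a number, so the step fixes only a minimum size. Little room is left for telling weak compounds apart: the limit of > 300000 nM in this assay, at which 2 of the 3 values shown sit.

The compounds shown leave open how a hydroxyl in place of methoxy would read. They also leave open whether an amine on this carbon would restore measurable inhibition.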